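Inversion at the ring stereocentre, compound 2 to compound 3

A few compounds are considered here, and "the series" means these few. Any claim that something is new, unique, unknown or untested is made for them only; others in the source may bear on it.

Compound 2 `CC(C)(C)C1=C(C(=O)O)N2C(=O)[C@H]([C@@H](O)c3ccccc3)[C@H]2O1` gives 8.9 h in an ADME assay, in phosphate buffer, at 28 degrees C, at pH 7.0; on this read-out higher numbers stand for a longer-lived compound and lower numbers for a shorter-lived compound; compound 1 `CC(C)(C)C1=C(C(=O)O)N2C(=O)[C@H]([C@H](O)c3ccccc3)[C@H]2O1` gives 7 h, and the two lie within the scatter of each other, so neither stands apart. For the measured compounds named here, the single measured step, a 1.3-fold higher number from compound 1 to compound 2 (0.10 log units; within the scatter), is a change in configuration alone because of the fact that compounds 1 and 2 differ only in the configuration as drawn, and it leaves the read-out where it was. Compound 3 `CC(C)(C)C1=C(C(=O)O)N2C(=O)[C@H]([C@@H](O)c3ccccc3)[C@@H]2O1` differs from compound 2 again in configuration alone: the two compounds have the same atoms and bonds and differ only in configuration as drawn: 1 of 3 stereo elements differ; a stereocentre at a saturated ring carbon is drawn R in compound 2 and S in compound 3. Going by the values given here, no measured step touches this ring stereocentre; the step from compound 1 to compound 2 concerns the chain carbon, so it bears on the present change only in the loose sense that one stereo inversion left the read-out within the scatter. On these data alone, on that basis no step beyond the scatter is expected in this assay, in either direction, though the ring centre itself is untested and the range is kept wide. Compound 3 is therefore estimated at 8.5 h, between 3.5 h and 20 h, an expected step of a 1.0-fold lower number from compound 2 to compound 3 (0.02 log units; within the scatter).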

Compound 3, half-life: 2.2 h
Beside the measured number, compound 3's estimate is 3.9-fold (0.59 log units) above it, outside the stated range (below it).
By their numbers in this assay, from the lowest: compound 3; then compounds 1 and 2 (each within the scatter of the next).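

In this assay, for the compounds shown here, the ring stereocentre is the first position where configuration alone moves the read-out beyond the scatter: a 4.0-fold lower number from compound 2 to compound 3 (0.61 log units; beyond the scatter). The chain stereocentre gave no such separation, so the two stereocentres of the series do not behave alike on this read-out. The other new step is also beyond the scatter, a 3.2-fold lower number from compound 1 to compound 3 (0.50 log units; beyond the scatter), but that pair differs at both centres and cannot assign the shift to either one, while the cleaner pair has no change in atoms or bonds to account for it: the fact that compounds 2 and 3 differ only in the configuration as drawn

The mechanism behind the shorter half-life of compound 3 remains open, as the compounds shown give no read-out that could explain it. Also open, on these data alone, is whether the ring inversion has a similar effect when an amine or a longer chain is carried on the shared core.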